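From Methoxyphenoxy to Methoxyphenyl on the Shared Core

The source may hold more compounds than are shown below. What is called first, only, known or untested is meant among the compounds shown, and "the series" means these compounds.

Compound 3 `COc1ccccc1Oc1ccc([C@H]2S[C@@H](C)C(=O)Nc3c2c(C)nn3-c2ccccc2C)cc1` gives the largest maximal response of the three compounds measured in an assay on isolated protein for agonist activity at Bile acid receptor (Homo sapiens), read by AlphaScreen, with a stated time of 30 min (a higher number here means a larger maximal response, a lower number a smaller maximal response), reaching 240%. Compound 2 `COc1ccc(Oc2ccc([C@H]3S[C@@H](C)C(=O)Nc4c3c(C)nn4-c3ccccc3C)cc2)cc1` reaches 70%, and compound 1 `Cc1ccccc1-n1nc(C)c2c1NC(=O)[C@H](C)S[C@@H]2c1ccc(-c2ccoc2)cc1` reaches 40%; the steps of a number 170 percentage points higher from compound 2 to compound 3 (beyond the scatter) and a number 200 percentage points higher from compound 1 to compound 3 (beyond the scatter) set compound 3 well apart. Compound 4 `COc1ccccc1-c1ccc([C@H]2S[C@@H](C)C(=O)Nc3c2c(C)nn3-c2ccccc2C)cc1` differs from compound 3 by 2-methoxyphenyl in place of 2-methoxyphenoxy on an aromatic carbon. Among the measured compounds shown here, no measured step removes the oxygen that links the two aromatic rings; the known steps, a number 30 percentage points higher from compound 1 to compound 2 (beyond the scatter), a number 200 percentage points higher from compound 1 to compound 3 (beyond the scatter) and a number 170 percentage points higher from compound 2 to compound 3 (beyond the scatter), alter only the distal group itself. Compound 3 stands far above compound 2 and compound 1. A change at this position seems more likely to lower than to raise the response, though the direction is uncertain. Compound 4 is therefore expected to reach 150% in this assay, between 60% and 260%, an estimated step of a number 90 percentage points lower from compound 3 to compound 4 (beyond the scatter).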

Compound 4, largest response reached (reported as efficacy), in percent of the reference or control that the assay uses: 50%
Compound 4: middle estimate off by 100 percentage points, on the high side; measured number below the stated range.
By their numbers in this assay, from the lowest: compounds 1 and 4 (each within the scatter of the next); then compound 2; then compound 3.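

Removing the linking oxygen takes away most of the response: 2-methoxyphenyl in place of 2-methoxyphenoxy gives a number 190 percentage points lower from compound 3 to compound 4 (beyond the scatter), so the methoxyphenyl ring alone does not carry the high response of compound 3. Against the other two groups, the same change gives much smaller steps: a number 20 percentage points lower from compound 2 to compound 4 (beyond the scatter) and a number 10 percentage points higher from compound 1 to compound 4 (within the scatter). Nothing available explains why the oxygen link matters so much here.

As far as these compounds go, whether a methylene or an amine nitrogen could replace the oxygen and keep the response remains open. So does whether 4-methoxyphenyl, joined directly, would differ from 2-methoxyphenyl.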